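This account rests on a few compounds, and the source may have more. Where it says the series, first, only, none or still open, it means among the compounds named here.

In a functional assay on KYSE-450 cells (Homo sapiens) for inhibition, read by MTT assay, with a stated time of 48 h (on this read-out higher numbers stand for weaker inhibition and lower numbers for stronger inhibition), compound 1 (`CCC/C=C/C(=O)N(Cc1ccc(OC)c(O)c1)c1cc(OC)c(OC)c(OC)c1`) gives 57 nM and compound 2 (`COc1ccc(CN(C(=O)C2CC2)c2cc(OC)c(OC)c(OC)c2)cc1O`) gives 80 nM. These two numbers do not separate the compounds, so compound 2 stands level with compound 1 within the usual scatter of such measurements. The next compound to be tested, compound 3 (`COc1ccc(CN(C(=O)CBr)c2cc(OC)c(OC)c(OC)c2)cc1O`), keeps the shared core and carries bromomethyl in place of cyclopropyl on a carbonyl carbon. Within the data shown here, only one measured step bears on this change. It concerns the same carbonyl carbon, and that step is small: a 1.4-fold higher number from compound 1 to compound 2 (0.15 log units; within the scatter). Among the measured compounds shown here, it replaced pent-1-en-1-yl with cyclopropyl, so it offers only thin evidence, and no compound with bromomethyl at this place has been measured yet. No shift beyond the scatter is therefore expected in either direction, although the uncertainty remains wide. The expected step is a 1.1-fold lower number from compound 2 to compound 3 (0.06 log units; within the scatter). The estimate for compound 3 is 70 nM, with an expected range from 20 nM to 300 nM.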

Compound 3, half-maximal inhibitory concentration: 120 nM
The estimate for compound 3 lay 1.7-fold (0.23 log units) below the measured number, within the range that was stated.
By their numbers in this assay, from the lowest: compounds 1, 2 and 3 (each within the scatter of the next, the first and the last beyond it).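

At this carbonyl carbon, this assay accepts a group of quite another kind: the change gives a 1.5-fold higher number from compound 2 to compound 3 (0.18 log units; within the scatter), so bromomethyl, which has no ring and carries a bromine atom, stands level with cyclopropyl. Compared with the pent-1-en-1-yl group of compound 1, the same bromomethyl group gives a 2.1-fold higher number from compound 1 to compound 3 (0.32 log units; beyond the scatter), the only step among these three compounds that passes the scatter, and it does so only modestly. Compound 2 lies within the scatter of both other compounds, so the three groups fall in a narrow band rather than in clearly separate levels, and nothing shown here accounts for the small gap between compound 1 and compound 3.

The compounds shown place only a carbon chain, a small carbon ring and bromomethyl on this carbonyl carbon, so three groups cannot show how far this narrow band extends. From the compounds shown here alone, it remains open how this assay would respond to an aminomethyl group, a carboxylic acid or a longer saturated chain at this place, and whether chloromethyl would stand level with bromomethyl.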